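Aryl ester cytotoxicity series: working notes

The source may report more compounds than this note shows. Statements on the series, on what has been measured and on what is new or still open speak of the compounds shown alone.

Measured so far in a functional assay on MDA-MB-231 cells (Homo sapiens) for cytotoxicity, read by MTT assay, with a stated time of 48 h; a higher number here means a weaker inhibitor, a lower number a stronger inhibitor:
compound 1 `Cc1ccc(C(C)C)c(OC(=O)c2cn(-c3ccccc3)nc2-c2cccnc2)c1`: > 100000 nM (a limit, not a number)
compound 2 `CC(C)c1cccc(OC(=O)c2cn(-c3ccccc3)nc2-c2ccncc2)c1`: > 100000 nM (a limit, not a number)
compound 3 `CC(C)(C)c1ccc(OC(=O)c2cn(-c3ccccc3)nc2-c2ccncc2)cc1`: 34500 nM

For the measured compounds named here, compound 3 gives the only number in this assay; the other two values are limits. Going by the values given here, the one step that is measured, an at least 2.8-fold lower number from compound 2 to compound 3 (0.46 log units; beyond the scatter), runs downward and goes beyond the scatter, resting on (the limit of > 100000 nM in this assay, at which 2 of the 3 values shown sit).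

Compound 4 is `Cc1ccc(C(C)C)c(OC(=O)c2cn(-c3ccccc3)nc2-c2ccncc2)c1`, not yet measured in this assay. It differs from compound 3 as 2-isopropyl-5-methylphenyl in place of 4-(tert-butyl)phenyl on an oxygen next to a carbonyl group. The measured step bears on it in reverse: compound 2 carries a branched isopropylphenyl ester and sits at a limit, whereas compound 3 with the 4-(tert-butyl)phenyl group gives a number, so returning to an isopropyl-bearing phenyl is expected to raise the number. Compound 1, which carries the same 2-isopropyl-5-methylphenyl group on a different core, also sits at a limit. Compound 4 is therefore expected to show an upward step, a 2.9-fold higher number from compound 3 to compound 4 (0.46 log units; beyond the scatter), beyond the scatter. Compound 4 is estimated at 100000 nM, with a range of 30000 nM to 300000 nM, and a real chance that only a limit is reported.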

Compound 4, half-maximal inhibitory concentration: > 100000 nM
Compound 4: a limit, no number; the forecaster's own chance of this, stated with the estimate: 60%; the middle value sits exactly at the limit.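

With the same atoms joined differently, 2-isopropyl-5-methylphenyl in place of 4-(tert-butyl)phenyl on an oxygen next to a carbonyl group gives an at least 2.8-fold higher number from compound 3 to compound 4 (0.46 log units; beyond the scatter), so in this assay the arrangement of the carbons in this group alone separates a number from a limit. For the compounds shown here, compound 3 remains the only compound here with a number, and the 2-isopropyl-5-methylphenyl group now gives a limit with both pyridin-3-yl in compound 1 and pyridin-4-yl in compound 4. The steps to compound 4 from compound 1 and from compound 2 cannot be read, both ends being limits: the limit of > 100000 nM in this assay, at which 3 of the 4 values shown sit.

As far as these compounds go, how far compound 1, compound 2 and compound 4 lie past that limit stays open, so no order among them can be given. Also open, from the compounds shown here alone, is whether an amine or a carboxylic acid on the phenyl ring of compound 3, or a chain longer than its tert-butyl, would lower the number in this assay.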